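Swapping a hydrazone arm for a pyrazolone ring

A few compounds are considered here, and "the series" means these few. Any claim that something is new, unique, unknown or untested is made for them only; others in the source may bear on it.

Compound 1, with structure `Cc1c(C(N)=O)sc2nc(N/N=C/c3ccc(Br)cc3)n(Cc3ccccc3)c(=O)c12`, was tested in a functional assay on the whole organism (strain albino) for inhibition, with Rattus norvegicus as the target, read by paw edema, in the formalin test, with stated times of 1 h and 2 h, at a dose of 10 mg/kg by the oral route (a lower number here means less inhibition, a higher number more inhibition at the dose given (going by the name of the read-out)), where compound 1 gives 39%. Among the measured compounds shown here, that is the lowest of the two numbers so far recorded. Its nearest neighbour, compound 2 with structure `Cc1c(C(N)=O)sc2nc(-n3nc(-c4ccc(Cl)cc4)cc3N)n(Cc3ccccc3)c(=O)c12`, gives 52% in this assay, a difference that lies beyond the scatter of repeated measurements.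

Compound 3, with structure `CC1=NN(c2nc3sc(C(N)=O)c(C)c3c(=O)n2Cc2ccccc2)C(=O)C1`, has not yet been measured. It differs from compound 1 in one place: a group of 7 heavy atoms (4 carbon, 2 nitrogen, 1 oxygen; one five-membered non-aromatic ring with 2 hetero atoms) in place of a group of 10 heavy atoms (7 carbon, 2 nitrogen, 1 bromine; one six-membered aromatic ring of carbon only), on an aromatic carbon. The group that leaves carries one hydrogen-bond donor; the group that enters carries none, and it brings one five-membered non-aromatic ring with two hetero atoms where a six-membered aromatic ring of carbon only stood before.

For the measured compounds named here, no step between measured compounds offers a direct guide, so the expected change from compound 1 to compound 3 in this assay is judged small: the step of a number 5 percentage points higher from compound 1 to compound 3 (within the scatter) is expected to sit within the usual scatter. Compound 3 is estimated to give 44% in this assay, in a range from 30% to 58%.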

Compound 3, a percentage reported as inhibition, in the whole organism at one dose (the size of the read-out at that dose, not a potency): 48%
For compound 3 the middle estimate is 4 percentage points below the measured one; the range from low to high includes it.
By their numbers in this assay, from the lowest: compounds 1, 3 and 2 (each within the scatter of the next, the first and the last beyond it).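

In this assay the exchange at the aromatic carbon between two ring nitrogen atoms, from the hydrazone arm with its six-membered aromatic ring of carbon only to the smaller five-membered non-aromatic ring, comes to a number 9 percentage points higher from compound 1 to compound 3 (within the scatter) and so moves the read-out by no more than repeated measurements would. The entering group carries no hydrogen-bond donor and no aromatic ring of its own, yet this single pair shows that the read-out at this position does not depend on keeping either feature. Nothing available here explains why the read-out holds across this exchange.

From the compounds shown here alone, whether a simple amine or a carboxylic acid on this same aromatic carbon would hold the read-out stays open. So does the question of whether the pyrazolone ring would keep its place with a longer chain in place of its methyl group.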